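The source may hold more compounds than are shown below. What is called first, only, known or untested is meant among the compounds shown, and "the series" means these compounds.

In a functional assay on CHO-K1 cells for agonist activity at Glucose-dependent insulinotropic receptor (Homo sapiens), read by HTRF and cAMP accumulation, with a stated time of 30 min (a lower number here means a smaller maximal response, a higher number a larger maximal response), three compounds have been measured. Compound 1 `CC(C)(C)OC(=O)N1CCC(CCCOc2ccc3c(c2)CCS3(=O)=O)CC1` gives 84%, compound 2 `CC(C)(C)OC(=O)N1CCC(CCCNc2ccc3c(c2)NNS3(=O)=O)CC1` gives 99%, and compound 3 `CCc1cnc(N2CCC(CCCNc3ccc4c(c3)OCC4=O)CC2)nc1` gives 115%. Compound 3 thus shows the largest maximal response of the three: its nearest neighbour is compound 2, lying beyond the scatter below it, and compound 1 lies further below, also beyond the scatter.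

The next compound, compound 4 `CC(C)c1noc(N2CCC(CCCNc3ccc4c(c3)OCC4=O)CC2)n1`, differs from compound 3 in one place: 3-isopropyl-1,2,4-oxadiazol-5-yl in place of 5-ethylpyrimidin-2-yl on an amine nitrogen in a ring. The rest of the molecule is unchanged. Among the compounds with values here, since no earlier pair of measured compounds shares this kind of exchange, the expected step from compound 3 to compound 4, a number 7 percentage points lower from compound 3 to compound 4 (within the scatter), is small and within the scatter. Compound 4 is therefore expected to reach about 108%, between 92% and 124%.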

Compound 4, largest response reached (Emax), in percent of the reference or control that the assay uses: 94%
For compound 4 the middle estimate is 14 percentage points above the measured one, within the range that was stated.
By their numbers in this assay, from the lowest: compounds 1, 4 and 2 (each within the scatter of the next, the first and the last beyond it); then compound 3.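

In this assay, within the data shown here, the group on the amine nitrogen in a ring matters: with the rest of the molecule unchanged, 3-isopropyl-1,2,4-oxadiazol-5-yl in place of 5-ethylpyrimidin-2-yl gives a number 21 percentage points lower from compound 3 to compound 4 (beyond the scatter) as the first readable step at this position. The two groups hold the same number of heavy atoms, so that count alone does not set the maximal response here. No measurement at hand explains the step. Open, on these data alone, is whether the ring or its alkyl group carries the step: a 3-ethyl-1,2,4-oxadiazol-5-yl, keeping the ethyl while exchanging the ring, would separate the two.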